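The compounds below may be only part of what the source reports. "The series", "measured", "known", "first", "only" and "open" are said of these compounds alone.

Among the measured compounds shown here, compound 2, `C[C@@H](NC(=O)OCC(F)(F)C(F)F)c1nc2ccc(F)cc2s1`, is one of only two compounds measured so far. In a physicochemical assay for lipophilicity, using the shake flask method, measured as octanol-water partition, with a stated time of 15 min (a lower number here means a more polar compound, a higher number a more lipophilic compound), compound 2 gives 2.92, while compound 1, `C[C@@H](NC(=O)OCC(F)(F)F)c1nc2ccc(F)cc2s1`, gives 2.69; the step of a number 0.23 log units higher from compound 1 to compound 2 (within the scatter) lies within the scatter, so the two compounds cannot be separated on this number alone. Compound 3, `C[C@@H](NC(=O)OCC(F)(F)C(F)(F)C(F)(F)F)c1nc2ccc(F)cc2s1`, has not yet been measured in this assay. It differs from compound 2 in one place: trifluoromethyl in place of hydrogen on a saturated chain carbon bound to two fluorine atoms and a saturated chain carbon. For the measured compounds named here, the one measured step that bears on this change is a number 0.23 log units higher from compound 1 to compound 2 (within the scatter), which extended the same fluorinated chain at the same place and gave a shift too small to stand clear of the scatter. The change to compound 3 is of the same kind but adds a larger group, so a shift in the same direction, of about the same size or somewhat larger, is expected, with a number 0.38 log units higher from compound 2 to compound 3 (beyond the scatter) the step estimated from compound 2. On that basis compound 3 is expected in this assay to come in at about 3.3, with a likely range from 3.05 to 3.6.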

Compound 3, partition coefficient: 3.2
Estimate against measurement, compound 3: 0.10 log units above; low and high end bracket the measured number.
By their numbers in this assay, from the lowest: compounds 1, 2 and 3 (each within the scatter of the next, the first and the last beyond it).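

In this assay the step of a number 0.28 log units higher from compound 2 to compound 3 (within the scatter) stays inside the scatter, as did the step of a number 0.23 log units higher from compound 1 to compound 2 (within the scatter) earlier, so neither of these two changes separates its pair of compounds when taken alone. Among the compounds shown here, what the new compound adds is the first clear separation at this position: the step of a number 0.51 log units higher from compound 1 to compound 3 (beyond the scatter) stands outside the scatter, though it is modest, and it comes from 1,1,2,2,2-pentafluoroethyl in place of fluoro on a saturated chain carbon bound to two fluorine atoms and a saturated chain carbon. Nothing at hand accounts for this shift.

On these data alone, all three compounds share the same core and differ only in this fluorinated chain, so it remains open how this assay would read for a plain ethyl or propyl chain without fluorine, or for a chain ending in a hydroxyl group or an amine. As far as these compounds go, it is also open whether a longer fluorinated chain, such as nonafluorobutyl, would carry the numbers further in the same direction or would leave them where compound 3 stands.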